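The compounds below may be only part of what the source reports. "The series", "measured", "known", "first", "only" and "open" are said of these compounds alone.

Measured compounds:
compound 1 `CNc1nc(Nc2ccc(C)c([N+](=O)[O-])c2)ncc1C(=O)Nc1cc(NC(=O)c2ccc(OC)cc2)ccc1C` — 1530 nM
compound 2 `CNc1nc(Nc2ccc(C)c([N+](=O)[O-])c2)ncc1C(=O)Nc1cc(NC(=O)c2ccc(OC)c(OC)c2)ccc1C` — 680 nM
compound 3 `CNc1nc(Nc2ccc(C)c(N)c2)ncc1C(=O)Nc1cc(NC(=O)c2ccc(OC)cc2)ccc1C` — 610 nM

All three were tested in a functional assay on K562 cells (Homo sapiens) for antiproliferative activity, read by CellTiter-Glo and CCK-8 assay, with a stated time of 72 h; a higher number here means a weaker inhibitor of growth, a lower number a stronger inhibitor of growth. Compound 1 gives 1530 nM, compound 2 gives 680 nM, and compound 3 gives 610 nM. The change from compound 1 to compound 2 is methoxy in place of hydrogen on an aromatic carbon, and in this assay it made a step of a 2.3-fold lower number from compound 1 to compound 2 (0.35 log units; beyond the scatter). Compound 3 differs from compound 1 in its core by amino in place of nitro on an aromatic carbon, which gave a step of a 2.5-fold lower number from compound 1 to compound 3 (0.40 log units; beyond the scatter). Compounds 2 and 3 lie within the scatter of each other.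

Compound 4 `CNc1nc(Nc2ccc(C)c(N)c2)ncc1C(=O)Nc1cc(NC(=O)c2ccc(OC)c(OC)c2)ccc1C` has not yet been measured. It differs from compound 3 by methoxy in place of hydrogen on an aromatic carbon, and the surroundings of that place match those of the change from compound 1 to compound 2 word for word, so this is the same change on the core of compound 3. Its step is therefore expected to resemble the earlier one, giving an estimated 2.0-fold lower number from compound 3 to compound 4 (0.31 log units; beyond the scatter), resting on a 2.3-fold lower number from compound 1 to compound 2 (0.35 log units; beyond the scatter). On that basis compound 4 is expected to give about 300 nM in this assay, likely between 120 nM and 700 nM.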

Compound 4, concentration for 50% growth inhibition: 380 nM
Compound 4: the middle estimate sits 1.3-fold (0.10 log units) below what was measured, within the range that was stated.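

In this assay, going from 4-methoxyphenyl to 3,4-dimethoxyphenyl on the amino core gave a 1.6-fold lower number from compound 3 to compound 4 (0.21 log units; within the scatter), and this step agrees with the one seen on the nitro core: the same change on two cores in this assay, a 2.3-fold lower number (0.35 log units; beyond the scatter) from compound 1 to compound 2 and a 1.6-fold lower number (0.21 log units; within the scatter) from compound 3 to compound 4, 1.4-fold (0.15 log units) apart, within the scatter of two such steps. Amino in place of nitro, made on the core carrying 3,4-dimethoxyphenyl, gave a 1.8-fold lower number from compound 2 to compound 4 (0.25 log units; within the scatter), and this step also agrees with its earlier counterpart: the same change on two cores in this assay, a 2.5-fold lower number (0.40 log units; beyond the scatter) from compound 1 to compound 3 and a 1.8-fold lower number (0.25 log units; within the scatter) from compound 2 to compound 4, 1.4-fold (0.15 log units) apart, within the scatter of two such steps. Each change therefore carried from one core to the other without a detectable difference in step size, but this rests on a single pair of steps per change. Both new steps lie within the scatter. They do not establish a real effect of either change on its new core.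

On these data alone, it remains open whether the same agreement would hold for an ethoxy group or a chlorine atom in place of the added methoxy. As far as these compounds go, it is equally open whether it would hold for an acetamide in place of the amino group.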